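A few compounds are considered here, and "the series" means these few. Any claim that something is new, unique, unknown or untested is made for them only; others in the source may bear on it.

For the measured compounds named here, compound 2, with the structure `CC(=O)N1N=C(c2cc(O)c(O)c([N+](=O)[O-])c2)CC1c1cccc(O)c1`, is one of two compounds measured so far in an assay on isolated protein for inhibition of Amine oxidase [flavin-containing] A (Homo sapiens), read by fluorescence; on this read-out lower numbers stand for stronger inhibition and higher numbers for weaker inhibition; in that assay compound 2 gives 87000 nM. The other measured compound, compound 1 `CC(=O)N1N=C(c2cc(O)c(O)c([N+](=O)[O-])c2)CC1c1ccc(C#N)cc1`, gives 76600 nM in this assay, and the two numbers lie within the usual scatter of each other, so neither can be said to stand apart from the other. Going by the values given here, the step of a 1.1-fold higher number from compound 1 to compound 2 (0.06 log units; within the scatter) is the only measured step, and it shows no change beyond the scatter.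

Compound 3, with the structure `CC(=O)N1N=C(c2cc(O)c(O)c([N+](=O)[O-])c2)CC1c1cccc(C#N)c1`, is not yet measured in this assay. It differs from compound 2 by cyano in place of hydroxy on an aromatic carbon. Among the compounds with values here, the one measured step bears on this change in part, since it already exchanges a cyano group for a hydroxy group on the same phenyl ring, although at a different position, and it stayed within the scatter. On that basis no step beyond the scatter is expected in this assay for compound 3, and the expected step of a 1.1-fold lower number from compound 2 to compound 3 (0.04 log units; within the scatter) is taken as essentially flat. Compound 3 is therefore estimated to give 80000 nM in this assay, with a range from 40000 nM to 160000 nM.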

Compound 3, half-maximal inhibitory concentration: 70600 nM
Compound 3: middle estimate off by 1.1-fold (0.05 log units), on the high side, and the stated range covers the measured number.
By their numbers in this assay, from the lowest: compounds 3, 1 and 2 (each within the scatter of the next).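

With the ring position held fixed, cyano in place of hydroxy on the aromatic carbon gives a 1.2-fold lower number from compound 2 to compound 3 (0.09 log units; within the scatter) in this assay, so this exchange can now be read on its own, without the shift of position that came with it in the earlier step, and it does not move the number beyond the scatter even though a hydrogen-bond donor leaves with the hydroxy. For the compounds shown here, the position of the nitrile can also be read separately for the first time: 3-cyanophenyl in place of 4-cyanophenyl gives a 1.1-fold lower number from compound 1 to compound 3 (0.04 log units; within the scatter) and also stays within the scatter, so neither the group at this position nor the placement of the nitrile separates these three compounds. Nothing available here accounts for this flat result.

The compounds shown leave open whether an amine, a carboxylic acid or a longer chain on this phenyl ring would give a step beyond the scatter, since the hydroxy and cyano groups tell nothing about such groups. They also leave open whether any change to the shared core, which all three compounds carry unaltered, would move the number more than these changes on the phenyl ring do.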